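Adding a methyl to the weakest urea in the set

This account rests on a few compounds, and the source may have more. Where it says the series, first, only, none or still open, it means among the compounds named here.

Measured compounds:
compound 1, `Cc1cc(NC(=O)NC2CCCCC2)ccc1N1CCC(N2CCCC2C)C1`, 11.2 nM
compound 2, `Cc1cc(NC(=O)N2CCN(C)CC2)ccc1N1CCC(N2CCCC2C)C1`, 12.7 nM
compound 3, `CC(=O)N1CCN(C(=O)Nc2ccc(N3CCC(N4CCCC4C)C3)cc2)CC1`, 34.1 nM

These values come from an assay on CHO cells for displacement of a labelled ligand from histamine receptor H3 (Macaca mulatta), read by scintillation counting, with a stated time of 1 h; a higher number here means a weaker inhibitor, a lower number a stronger inhibitor. Compound 3 stands highest of the three, with compound 2 its nearest neighbour, below it beyond the scatter, and compound 1 furthest. Compound 4, `CC(=O)N1CCN(C(=O)Nc2ccc(N3CCC(N4CCCC4C)C3)c(C)c2)CC1`, is compound 3 with methyl in place of hydrogen on an aromatic carbon, the same methyl that compounds 1 and 2 already carry. Among the measured compounds shown here, the only measured step, a 1.1-fold higher number from compound 1 to compound 2 (0.05 log units; within the scatter), concerns the group on the carbonyl carbon, not this methyl, so no measured step bears directly on the change. Compounds 2 and 3 differ in two places, the methyl included, and their values suggest the methyl-bearing pattern sits lower. A modest lowering step is therefore expected, a 2.1-fold lower number from compound 3 to compound 4 (0.33 log units; beyond the scatter), and compound 4 is estimated at 16 nM, within 6 nM to 40 nM.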

Compound 4, inhibition constant: 23 nM
Compound 4: middle estimate off by 1.4-fold (0.16 log units), on the low side, and the stated range covers the measured number.
By their numbers in this assay, from the lowest: compounds 1, 2, 4 and 3 (each within the scatter of the next, the first and the last beyond it).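

In this assay, among the compounds shown here, methyl in place of hydrogen on an aromatic carbon gives a 1.5-fold lower number from compound 3 to compound 4 (0.17 log units; within the scatter) and so offers the first direct reading of this change, which does not separate the two compounds. For the compounds shown here, with that methyl present in all three compounds, acetyl in place of methyl on an amine nitrogen in a ring gives a 1.8-fold higher number from compound 2 to compound 4 (0.26 log units; within the scatter) while a different group on the carbonyl carbon gives a 2.1-fold higher number from compound 1 to compound 4 (0.31 log units; beyond the scatter) and only this last step lies beyond the scatter. Nothing available explains these steps.

The compounds shown leave open whether an ethyl or a methoxy group on this aromatic carbon would give a different number. They also leave open whether the methyl step would look the same with a carboxylic acid or a primary amine on the piperazine.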